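The source may report more compounds than this note shows. Statements on the series, on what has been measured and on what is new or still open speak of the compounds shown alone.

Measured compounds in an ADME assay on BEAS-2B cells (Homo sapiens) for cytotoxicity, read by MTT assay, with a stated time of 72 h; on this read-out lower numbers stand for stronger inhibition of growth and higher numbers for weaker inhibition of growth:
compound 1, `CCCCC[Se]c1nc(NCc2ccc(SC)cc2)c2ccccc2n1`, gives 34700 nM;
compound 3, `Sc1nc(NCc2ccccc2)c2ccccc2n1`, gives 66300 nM;
compound 2, `CCCCC[Se]c1nc([Se]CCCCC)c2ccccc2n1`, gives only a limit, > 100000 nM.

Compound 3 holds the higher of the two numbers reported in full in this assay. Compound 1 lies lower by an amount that is within the usual scatter, so the two cannot be ranked against each other. Compound 2 sits at the limit of > 100000 nM in this assay, at which 1 of the 3 values shown sits, and that value is a limit of the assay, not a number.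

Compound 4, `CCCCC[Se]c1nc(NCc2ccccc2)c2ccccc2n1`, has not been measured. It differs from compound 3 in one place: a group of 6 heavy atoms (5 carbon, 1 selenium; no ring) in place of one sulfur atom, on an aromatic carbon. Among the measured compounds shown here, no step between two measured compounds repeats this change, so its size cannot be read from the data. Compound 1 carries the same entering group on the shared core, with a further substituent on its benzyl ring, and gives 34700 nM, close to the number for compound 3. On this footing the step from compound 3 to compound 4 is expected to be small, if anything toward a lower number, and not beyond the scatter, as a 1.6-fold lower number from compound 3 to compound 4 (0.20 log units; within the scatter). Compound 4 is therefore estimated at 42000 nM, with a range from 15000 nM to 100000 nM.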

Compound 4, concentration for 50% growth inhibition: 44100 nM
Estimate against measurement, compound 4: 1.1-fold (0.02 log units) below; the measured number falls inside the stated range.
By their numbers in this assay, from the lowest: compounds 1, 4 and 3 (each within the scatter of the next). At a limit, above all of these: compound 2.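

In this assay, a group of 6 heavy atoms (5 carbon, 1 selenium; no ring) in place of sulfanyl, on the aromatic carbon between two ring nitrogen atoms, gives a 1.5-fold lower number from compound 3 to compound 4 (0.18 log units; within the scatter), and hydrogen in place of methylsulfanyl gives a 1.3-fold higher number from compound 1 to compound 4 (0.10 log units; within the scatter), so neither change registers beyond the scatter here. Among the compounds shown here, the one step beyond the scatter is the exchange on an aromatic carbon of a group of 6 heavy atoms (5 carbon, 1 selenium; no ring) for a group with one six-membered aromatic ring of carbon only, which gives an at least 2.2-fold lower number from compound 2 to compound 4 (0.35 log units; beyond the scatter). This step has only a lower bound on its size, since compound 2 gives a limit and not a number: the limit of > 100000 nM in this assay, at which 1 of the 4 values shown sits.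

The compounds shown leave open how much of the group of 6 heavy atoms matters, as none pairs the same chain with sulfur in place of selenium at this position. They also leave open how a shorter or longer chain, or an amine, on this aromatic carbon would read in this assay.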